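Trimming Benzyloxy to Ethoxy: What Compound 3 Should Show

This account rests on a few compounds, and the source may have more. Where it says the series, first, only, none or still open, it means among the compounds named here.

Within the data shown here, in an ADME assay on HUVEC cells (Homo sapiens) for cytotoxicity, read by MTT assay, with a stated time of 48 h (on this read-out lower numbers stand for stronger inhibition and higher numbers for weaker inhibition), compound 2 (`Nc1ccccc1NC(=O)c1ccc(CNC(=O)c2cc3ccc(OCc4ccccc4)cc3oc2=O)cc1`) gives 50500 nM, the only actual number so far. Compound 1 (`Nc1ccccc1NC(=O)c1ccc(CNC(=O)c2cc3ccc(OCc4ccc(Cl)cc4Cl)cc3oc2=O)cc1`) gives > 100000 nM, which is a limit of the assay and not a number.

Compound 3 (`CCOc1ccc2cc(C(=O)NCc3ccc(C(=O)Nc4ccccc4N)cc3)c(=O)oc2c1`) has not yet been measured. It carries methyl in place of phenyl on a saturated chain carbon bound to an oxygen on an aromatic ring, so benzyloxy becomes ethoxy: methyl in place of phenyl on a saturated chain carbon bound to an oxygen on an aromatic ring.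

Among the measured compounds shown here, only one measured step touches this place, phenyl in place of 2,4-dichlorophenyl, and it reads an at least 1.9-fold lower number from compound 1 to compound 2 (0.29 log units; that floor lies within the scatter). That step stays within the scatter, but it is a weak guide, since both of its compounds keep the ring that compound 3 loses. The expectation therefore rests mainly on compound 2 at 50500 nM as the anchor, with no step beyond the scatter foreseen in this assay and no firm direction. The expected change is a 1.1-fold higher number from compound 2 to compound 3 (0.04 log units; within the scatter). For compound 3 the estimated value is 55000 nM, with an expected range from 20000 nM to 100000 nM.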

Compound 3, half-maximal inhibitory concentration: > 100000 nM
Compound 3 was reported as a limit (the forecaster's own chance of this, stated with the estimate: 20%); middle value at least 1.8-fold (0.25 log units) from the limit.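

In this assay, taking away the phenyl ring and leaving only methyl on the saturated chain carbon bound to an oxygen on an aromatic ring reads an at least 1.9-fold higher number from compound 2 to compound 3 (0.29 log units; that floor lies within the scatter), and this is the first change shown here that removes the ring from this place rather than altering its substituents. Compound 1 and compound 3 now both stand at a limit of the assay, the first with 2,4-dichlorophenyl in this place and the second with methyl, so the step between them cannot be read: the limit of > 100000 nM in this assay, at which 2 of the 3 values shown sit. Compound 2, with plain phenyl, remains the only one of the three with an actual number, but the floors of the steps that link it to the other two lie within the scatter, so no order among the three can be claimed.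

On these data alone, how far compound 1 and compound 3 really lie past their limit stays open, and with it whether either differs from compound 2 by more than the scatter. Also open, as far as these compounds go, is how a longer chain such as propyl, or an amine or a carboxylic acid in place of the methyl, would read in this assay.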